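Swapping a thiazole for cyclopentyl on an adenosine hydrazone

A few compounds are considered here, and "the series" means these few. Any claim that something is new, unique, unknown or untested is made for them only; others in the source may bear on it.

Measured compounds:
compound 1, `Nc1nc(N/N=C/c2ccc(Br)cn2)nc2c1ncn2[C@@H]1O[C@H](CO)[C@@H](O)[C@H]1O`: 4.7 nM
compound 2, `Nc1nc(N/N=C/c2cncs2)nc2c1ncn2[C@@H]1O[C@H](CO)[C@@H](O)[C@H]1O`: 22 nM
compound 3, `COc1cc(/C=N/Nc2nc(N)c3ncn([C@@H]4O[C@H](CO)[C@@H](O)[C@H]4O)c3n2)cc(OC)c1OC`: > 10000 nM

All three share one core, a purine riboside carrying a hydrazone arm, and were tested in an assay on CHO-K1 cells for displacement of a labelled ligand from adenosine receptor A1 (Homo sapiens), read by scintillation counting, with a stated time of 60 min; on this read-out higher numbers stand for weaker inhibition and lower numbers for stronger inhibition. Compound 1 gives 4.7 nM and compound 2 gives 22 nM. For compound 3 the assay returns only a limit, > 10000 nM, not a number. For the measured compounds named here, the one step between measured compounds that differ in a single place is a 4.7-fold higher number from compound 1 to compound 2 (0.67 log units; beyond the scatter). Compound 2 therefore stands at the higher of the two numbers, with compound 1 the nearer and stronger one.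

Compound 4, `Nc1nc(N/N=C/C2CCCC2)nc2c1ncn2[C@@H]1O[C@H](CO)[C@@H](O)[C@H]1O`, has not been measured. It differs from compound 2 by cyclopentyl in place of 1,3-thiazol-5-yl on a carbon with a double bond to nitrogen. Going by the values given here, neither the single measured step nor the limit of compound 3 describes an exchange of an aromatic heterocycle for a saturated carbon ring, so there is no direct precedent. Given that the measured step was modest and that compound 3 reached the limit (the limit of > 10000 nM in this assay, at which 1 of the 3 values shown sits), a moderate weakening is expected, a 2.7-fold higher number from compound 2 to compound 4 (0.44 log units; beyond the scatter). Compound 4 is thus estimated at 60 nM, between 10 nM and 400 nM.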

Compound 4, inhibition constant: 5.6 nM
For compound 4 the middle estimate is 11-fold (1.03 log units) above the measured one; the measured number lies below the stated range.
By their numbers in this assay, from the lowest: compounds 1 and 4 (each within the scatter of the next); then compound 2. At a limit, above all of these: compound 3.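

In this assay the exchange gives a 3.9-fold lower number from compound 2 to compound 4 (0.59 log units; beyond the scatter) and so shows that this position, on a carbon with a double bond to nitrogen, does not need an aromatic ring to reach a low number. The entering cyclopentyl ring is carbon only and has no hydrogen-bond acceptors, so neither the sulfur and nitrogen of 1,3-thiazol-5-yl nor its acceptors are required for a low number here. Set against the other aromatic group, cyclopentyl in place of 5-bromopyridin-2-yl gives a 1.2-fold higher number from compound 1 to compound 4 (0.08 log units; within the scatter) and this puts compounds 1 and 4 on a par, so a plain saturated ring does as well here as that bromine-bearing ring.

As far as these compounds go, whether other groups at this place, such as cyclohexyl, a longer carbon chain or an amine, would keep numbers this low remains open, as does how much the size of the ring matters. The compounds shown offer no measured reason why cyclopentyl gives a lower number than 1,3-thiazol-5-yl.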